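Trading a hydroxypyrrolidine sulfonamide for an isopropyl sulfone

This account rests on a few compounds, and the source may have more. Where it says the series, first, only, none or still open, it means among the compounds named here.

Compound 1 `CCN(CC)S(=O)(=O)c1ccc(S(=O)(=O)N2CCC[C@@H](C(=O)N[C@H]3CC[C@H](OC)CC3)C2)cc1` gives > 10000 nM in a functional assay on MIA PaCa-2 cells (Homo sapiens) for inhibition, read by MTT assay, with a stated time of 3 days (a higher number here means a weaker inhibitor, a lower number a stronger inhibitor), which is a limit of the assay and not a number. Compound 3 `CCN(CC)S(=O)(=O)c1ccc(S(=O)(=O)N2CCC[C@@H](C(=O)N3CCC(OC)CC3)C2)cc1` likewise reaches only the limit > 10000 nM in this assay. The step that the two limits leave unreadable from compound 1 to compound 3 is therefore unreadable. Among the compounds with values here, compound 2 `O=C([C@@H]1CCCN(S(=O)(=O)c2ccc(S(=O)(=O)N3CC[C@@H](O)C3)cc2)C1)N1CCC(F)(F)CC1` gives > 3000 nM in this assay, again a limit, so compound 2 stands without a number of its own; every value so far is a limit, as the limit of > 10000 nM in this assay, at which 2 of the 3 values shown sit, and the limit of > 3000 nM in this assay, at which 1 of the 3 values shown sits, record. Compound 4 `CC(C)S(=O)(=O)c1ccc(S(=O)(=O)N2CCC[C@@H](C(=O)N3CCC(F)(F)CC3)C2)cc1` differs from compound 2 by isopropyl in place of 3-hydroxypyrrolidin-1-yl on a sulfonyl sulfur. Within the data shown here, no measured step touches the sulfonyl sulfur, so nothing guides the direction. Compound 4 is expected near the limits, with a step that the limit leaves unreadable from compound 2 to compound 4 estimated as no step beyond the scatter, giving 5000 nM (range 1500 nM to 20000 nM).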

Compound 4, half-maximal inhibitory concentration: > 3000 nM
Compound 4 gave a limit, no number; the forecaster's own chance of this, stated with the estimate: 65%; the middle value lies beyond the limit too.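

In this assay compound 4 gives > 3000 nM which is a limit and not a number. Compound 2 also stands at a limit, so no step can be read between compound 2 and compound 4. The compounds shown leave open whether any group on the sulfonyl sulfur gives a measurable inhibition.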